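Varying the aryl cap on the piperazine amide

A few compounds are considered here, and "the series" means these few. Any claim that something is new, unique, unknown or untested is made for them only; others in the source may bear on it.

Compound 1 `CCOC(=O)COc1cc(-c2cc(=O)c3c(O)cc(OCC(=O)N4CCN(Cc5ccc(OC)c(OC)c5OC)CC4)cc3o2)ccc1OC`: > 70000 nM
Compound 2 `COc1ccc(-c2cc(=O)c3c(O)cc(OCC(=O)N4CCN(Cc5ccc(OC)c(OC)c5OC)CC4)cc3o2)cc1OCC(=O)N1CCN(Cc2ccc(OC)c(OC)c2OC)CC1`: 1000 nM
Compound 3 `CCOC(=O)COc1cc(-c2cc(=O)c3c(O)cc(OCC(=O)N4CCN(Cc5c(OC)cc(OC)cc5OC)CC4)cc3o2)ccc1OC`: 9500 nM

In an ADME assay on MRC5 cells (Homo sapiens) for cytotoxicity (on this read-out higher numbers stand for weaker inhibition and lower numbers for stronger inhibition), compound 1 gives > 70000 nM, which is a limit of the assay and not a number. Among the two numbers, compound 3 has the higher one and compound 2 the lower, a gap beyond the scatter. Compound 4 `CCOC(=O)COc1cc(-c2cc(=O)c3c(O)cc(OCC(=O)N4CCN(Cc5ccc(O)c(OC)c5OC)CC4)cc3o2)ccc1OC` differs from compound 3 by 4-hydroxy-2,3-dimethoxyphenyl in place of 2,4,6-trimethoxyphenyl on a saturated chain carbon bound to an amine nitrogen in a ring. Going by the values given here, the only measured step at this place, an at least 7.3-fold lower number from compound 1 to compound 3 (0.86 log units; beyond the scatter), shows that rearranging the groups on this ring can move this assay beyond the scatter, but no measured step puts a hydroxy group here, so the direction is open. A moderate shift is therefore expected, a 1.6-fold higher number from compound 3 to compound 4 (0.20 log units; within the scatter). Compound 4 is estimated at 15000 nM in this assay, with a range from 3000 nM to 70000 nM.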

Compound 4, half-maximal inhibitory concentration: 10000 nM
For compound 4 the middle estimate is 1.5-fold (0.18 log units) above the measured one, and the stated range covers the measured number.
By their numbers in this assay, from the lowest: compound 2; then compounds 3 and 4 (each within the scatter of the next). At a limit, above all of these: compound 1.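

In this assay, hydrogen in place of methyl on an oxygen on the aromatic ring is enough to give an at least 7.0-fold lower number from compound 1 to compound 4 (0.84 log units; beyond the scatter), so a single edit on this ring can matter as much as rearranging its groups. The 4-hydroxy-2,3-dimethoxyphenyl and 2,4,6-trimethoxyphenyl caps read alike, with a 1.1-fold higher number from compound 3 to compound 4 (0.02 log units; within the scatter). Compound 1 stands at a limit and not a number: the limit of > 70000 nM in this assay, at which 1 of the 4 values shown sits.

From the compounds shown here alone, whether a hydroxy group on another carbon of this ring gives the same result stays open. So does the effect of an amine or a fluorine on this ring.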